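Amide nitrogen groups: the step to compound 3

The source may hold more compounds than are shown below. What is called first, only, known or untested is meant among the compounds shown, and "the series" means these compounds.

Compound 1 `C#CCNC(=O)/C=C/c1c(/C=C/c2ccc(OC)cc2)cc(OC)cc1OC` gives 4560 nM
Compound 2 `COc1ccc(/C=C/c2cc(OC)cc(OC)c2/C=C/C(=O)Nc2cc(OC)c(OC)c(OC)c2)cc1` gives 7010 nM

In a functional assay on MCF7 cells (Homo sapiens) for inhibition, read by MTT assay, with a stated time of 48 h (a higher number here means a weaker inhibitor, a lower number a stronger inhibitor), compound 2 gives 7010 nM and lies within the scatter of compound 1, so the two cannot be ordered. Compound 3 `CCCCCCNC(=O)/C=C/c1c(/C=C/c2ccc(OC)cc2)cc(OC)cc1OC` differs from compound 2 on an amide-type nitrogen, with hexyl in place of 3,4,5-trimethoxyphenyl on an amide-type nitrogen is the full difference. Going by the values given here, the only measured step at this nitrogen is a 1.5-fold higher number from compound 1 to compound 2 (0.19 log units; within the scatter) and it stays within the scatter. No hexyl group has been measured, so the evidence is thin and favours no direction. An estimated 1.3-fold lower number from compound 2 to compound 3 (0.11 log units; within the scatter) is expected to remain within the scatter in this assay as well. Compound 3 is expected at 5500 nM with an estimated range from 2000 nM to 15000 nM in this read-out.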

Compound 3, half-maximal inhibitory concentration: 5530 nM
The estimate for compound 3 lay 1.0-fold (0.00 log units) below the measured number; the range from low to high includes it.
By their numbers in this assay, from the lowest: compounds 1, 3 and 2 (each within the scatter of the next).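

In this assay, the step of a 1.3-fold lower number from compound 2 to compound 3 (0.10 log units; within the scatter) and the step of a 1.2-fold higher number from compound 1 to compound 3 (0.08 log units; within the scatter) both stay within the scatter, so a saturated hexyl chain joins propargyl and 3,4,5-trimethoxyphenyl on the amide-type nitrogen without any order among the three. Hexyl has no ring and no hydrogen-bond acceptors, unlike 3,4,5-trimethoxyphenyl, yet this difference gives no separation here. No available evidence bears on this result. On these data alone, whether an amine, a carboxylic acid or a longer chain on this nitrogen would move the number beyond the scatter remains open.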